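The source may hold more compounds than are shown below. What is called first, only, known or untested is meant among the compounds shown, and "the series" means these compounds.

Series notes: compound 1 `Clc1ccc(Oc2cncc(C3=CC4CNCC(C3)C4)c2)cc1` and compound 2 `COc1ccc(Oc2cncc(C3=CC4CNCC(C3)C4)c2)cc1` share a core that carries an aryloxy substituent; compound 3 `Clc1cncc(C2=CC3CNCC(C2)C3)c1` carries a chloro group on the core in its place, and the unmeasured compound 4 `COc1cncc(C2=CC3CNCC(C2)C3)c1` carries a methoxy there. The difference between the two cores is not broken down here.

In an in vitro assay on SH-EP1 cells for displacement of a labelled ligand from Neuronal acetylcholine receptor; alpha4/beta2 (Homo sapiens) (on this read-out higher numbers stand for weaker inhibition and lower numbers for stronger inhibition), compound 1 gives 1.9 nM, and compound 2 gives 1.4 nM. The change between them, (methoxy in place of chloro on an aromatic carbon), gives the step of a 1.4-fold lower number from compound 1 to compound 2 (0.13 log units; within the scatter). Compound 3 gives 0.4 nM in this assay, the lowest of the three numbers; its gap to compound 2 and its gap to compound 1 both lie beyond the scatter.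

The change from compound 3 to compound 4 is methoxy in place of chloro on an aromatic carbon. It is the same kind of change as in the measured pair, but the surroundings differ: there the methoxy entered on an aromatic carbon of a six-membered aromatic ring of carbon only, para to a large group, here it enters on an aromatic carbon of a six-membered aromatic ring with 1 nitrogen, two atoms from the ring nitrogen, meta to a group of 9 heavy atoms.

For compound 4 the step is expected to be no change at the digits printed from compound 3 to compound 4 (within the scatter) in this assay, resting on the step of a 1.4-fold lower number from compound 1 to compound 2 (0.13 log units; within the scatter) that lay within the scatter. The place is not the same, and the room is set wider. The expected value for compound 4 is 0.4 nM, between 0.15 nM and 1.1 nM.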

Compound 4, inhibition constant: 0.3 nM
Compound 4: middle estimate off by 1.3-fold (0.12 log units), on the high side, and the stated range covers the measured number.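

Methoxy in place of chloro on an aromatic carbon gives a 1.3-fold lower number from compound 3 to compound 4 (0.12 log units; within the scatter) in this assay and so matches the earlier step on the aryloxy core: the same change on two cores in this assay, a 1.4-fold lower number (0.13 log units; within the scatter) from compound 1 to compound 2 and a 1.3-fold lower number (0.12 log units; within the scatter) from compound 3 to compound 4, 1.0-fold (0.01 log units) apart, within the scatter of two such steps. Across these two cores the change therefore leaves the number within the scatter, although the group stands on a carbon-only ring in one pair and on a ring with 1 nitrogen in the other; two pairs in one assay do not show that this holds across the series, and steps this small cannot reveal any slight difference between the two groups. The larger steps in this set arise at the oxygen instead, with methyl in place of 4-methoxyphenyl giving a 4.7-fold lower number from compound 2 to compound 4 (0.67 log units; beyond the scatter) and methyl in place of 4-chlorophenyl giving a 6.3-fold lower number from compound 1 to compound 4 (0.80 log units; beyond the scatter), both beyond the scatter, yet neither pair says how much of that gap belongs to the aryl ring itself.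

Still open, on these data alone, is whether an amine, a nitrile or a longer chain such as ethoxy at this aromatic carbon would also stay within the scatter of chloro and methoxy. Also open, as far as these compounds go, is how the aryloxy core would respond to a carboxylic acid on its outer ring.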